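A few compounds are considered here, and "the series" means these few. Any claim that something is new, unique, unknown or untested is made for them only; others in the source may bear on it.

Measured so far:
compound 1, `COc1cc(-c2ccnc3cc(-c4ccc5cc[nH]c5c4)nn23)cc(OC)c1OC`: in a functional assay on B16-F0 cells (Mus musculus) for inhibition, read by CCK-8 assay, with a stated time of 48 h (a higher number here means a weaker inhibitor, a lower number a stronger inhibitor), compound 1 gives 55 nM
compound 2, `COc1cc(-c2ccnc3c(-c4ccc(C)cc4)cnn23)cc(OC)c1OC`: in this assay compound 2 gives > 10000 nM, which is a limit of the assay and not a number

Going by the values given here, compound 1 and compound 2 share the same core but differ in more than one place, so no single measured step joins them; their two values are simply set side by side. Among the compounds with values here, compound 1 supplies the only true number in this assay. Compound 2 sits at the limit of > 10000 nM in this assay, at which 1 of the 2 values shown sits.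

Compound 3, `COc1cc(-c2ccnc3cc(-c4ccc(N(C)C)cc4)nn23)cc(OC)c1OC`, has not yet been measured. It differs from compound 1 in one place: 4-(dimethylamino)phenyl in place of 1H-indol-6-yl on an aromatic carbon. The 1H-indol-6-yl leaves and the 4-(dimethylamino)phenyl enters on an aromatic carbon of a five-membered aromatic ring with two nitrogens, next to the ring nitrogen. Within the data shown here, no measured step of this kind is available to lean on, so the expectation rests on the change itself and on compound 1 alone.

Compound 3 is expected to give about 150 nM in this assay, within a range from 40 nM to 600 nM. This estimate means a step of a 2.7-fold higher number from compound 1 to compound 3 (0.44 log units; beyond the scatter), expected to be a small to moderate weakening, possibly still within the scatter.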

Compound 3, half-maximal inhibitory concentration: 702 nM
Estimate against measurement, compound 3: 4.7-fold (0.67 log units) below, outside the stated range (above it).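

In this assay, going by these compounds alone, putting 4-(dimethylamino)phenyl in place of 1H-indol-6-yl on this aromatic carbon of the five-membered aromatic ring gives a 13-fold higher number from compound 1 to compound 3 (1.11 log units; beyond the scatter), the first step here that changes only one place. This shows that the position is sensitive to the group it carries: the two groups have the same count of heavy atoms, 8 carbon and 1 nitrogen, yet they are far from interchangeable, although compound 3 still gives a true number of 702 nM rather than a limit. No measured property shown here accounts for the size of this step.

The step swaps a two-ring group with a hydrogen-bond donor for a one-ring group with a hydrogen-bond acceptor, so the effects of the ring change and of the donor and acceptor change cannot be separated. A group such as 4-aminophenyl, which keeps a single ring but carries a primary amine with its own hydrogens on nitrogen, or a plain phenyl with no nitrogen at all, would help to pull these changes apart.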